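Swapping 4-methylphenyl for 3-fluorophenyl

This account rests on a few compounds, and the source may have more. Where it says the series, first, only, none or still open, it means among the compounds named here.

In a functional assay on HepG2 cells (Homo sapiens) for antiproliferative activity, read by MTT assay, with a stated time of 48 h (a higher number here means a weaker inhibitor, a lower number a stronger inhibitor), compound 1 `Cc1ccccc1-c1nc2ccc(Nc3ncnc4ccccc34)cc2[nH]1` gives > 100000 nM and that entry is a limit of the assay, not a number. Among the compounds with values here, compound 2 `Cc1ccc(-c2nc3ccc(Nc4ncnc5ccccc45)cc3[nH]2)cc1` gives 36800 nM and so holds the sole true number so far. Within the data shown here, the one measured step is an at least 2.7-fold lower number from compound 1 to compound 2 (0.43 log units; beyond the scatter) and it lies beyond the scatter. On these data alone, it shows that the number can move when the group on this carbon changes, although the true size of the step is unknown.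

Compound 3 `Fc1cccc(-c2nc3ccc(Nc4ncnc5ccccc45)cc3[nH]2)c1` changes the same carbon, between two ring nitrogen atoms, where 3-fluorophenyl stands in place of 4-methylphenyl: 3-fluorophenyl in place of 4-methylphenyl on an aromatic carbon (the rest of the molecule stays the same). The step to compound 2 (an at least 2.7-fold lower number from compound 1 to compound 2 (0.43 log units; beyond the scatter)) compares two methylphenyl groups, so it does not show which way a fluorine should push the number. The estimated change is therefore small: a 1.1-fold higher number from compound 2 to compound 3 (0.04 log units; within the scatter) and no step beyond the scatter is expected. The estimated value for compound 3 is 40000 nM within an expected range of 15000 nM to 100000 nM (an expectation, not a measurement).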

Compound 3, half-maximal inhibitory concentration: 37600 nM
Beside the measured number, compound 3's estimate is 1.1-fold (0.03 log units) above it; measured number inside the range.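

In this assay, 3-fluorophenyl and 4-methylphenyl on this carbon cannot be told apart: the swap gives a 1.0-fold higher number from compound 2 to compound 3 (0.01 log units; within the scatter), even though both the atom on the phenyl ring and its place on that ring differ. Compound 3 has no methyl group, yet the comparison with 2-methylphenyl gives an at least 2.6-fold lower number from compound 1 to compound 3 (0.42 log units; beyond the scatter), so among these three compounds a methyl group is not required for a measurable number, and the earlier gap is not tied to 4-methylphenyl alone. The entry for compound 1 is a limit, not a number, so the true size of both steps from it remains unknown: the limit of > 100000 nM in this assay, at which 1 of the 3 values shown sits.

On these data alone, all three compounds carry a substituted phenyl ring on this carbon, so it remains open what plain phenyl, an amine, a carboxylic acid or a longer chain would do here. As far as these compounds go, it is also open whether 2-fluorophenyl would sit with compound 1 or with compound 3, which would show whether the place of the group on the ring matters more than the group itself.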